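The compounds below may be only part of what the source reports. "The series", "measured", "known", "first", "only" and "open" are said of these compounds alone.

Compound 3, `Nc1nonc1C(=O)Nc1cc(C(F)(F)F)cc(C(F)(F)F)c1`, carries a 4-amino-1,2,5-oxadiazol-3-yl group on the carbonyl carbon of its amide. In an assay on isolated protein for inhibition of mitogen-activated protein kinase kinase kinase 14 (Homo sapiens), read by ADP-Glo, with a stated time of 60 min, in the presence of a further agent that is not named here (on this read-out lower numbers stand for stronger inhibition and higher numbers for weaker inhibition), compound 3 gives only a limit of the assay, > 100000 nM. Its two companions stand in the same place. Compound 1, `COc1nsnc1C(=O)Nc1cc(C(F)(F)F)cc(C(F)(F)F)c1`, gives only a limit, > 100000 nM. Compound 2, `Cn1nnc(O)c1C(=O)Nc1cc(C(F)(F)F)cc(C(F)(F)F)c1`, likewise gives only a limit, > 100000 nM. The whole set therefore rests on (the limit of > 100000 nM in this assay, at which 3 of the 3 values shown sit), and every exchange of the five-membered ring on the carbonyl carbon leaves nothing to read: a step that the two limits leave unreadable from compound 1 to compound 2, a step that the two limits leave unreadable from compound 1 to compound 3 and a step that the two limits leave unreadable from compound 2 to compound 3 are all steps between two limits.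

Compound 4, `Cn1cc(C(=O)Nc2cc(C(F)(F)F)cc(C(F)(F)F)c2)c(O)n1`, continues this series with 3-hydroxy-1-methyl-1H-pyrazol-4-yl in place of 4-amino-1,2,5-oxadiazol-3-yl on a carbonyl carbon. Since no measured exchange of the ring on this carbonyl carbon produced a readable number, the step from compound 3 to compound 4 is expected to be a number no higher from compound 3 to compound 4 (the limit leaves the size open), no readable change, and compound 4 is expected to sit at 100000 nM, most likely reported again as a limit, with a range from 30000 nM to 300000 nM.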

Compound 4, half-maximal inhibitory concentration: > 100000 nM
Compound 4 gave a limit, no number; the forecaster's own chance of this, stated with the estimate: 85%; the middle value lies on the limit itself.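

In this assay compound 4 gives > 100000 nM, a limit and not a number. Its steps from compound 1, compound 2 and compound 3 all lie between two limits and cannot be read. The compounds shown leave open whether any ring on this carbonyl carbon would give a readable number in this assay, for the whole set rests on one limit: the limit of > 100000 nM in this assay, at which 4 of the 4 values shown sit.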